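The compounds below may be only part of what the source reports. "The series", "measured", "known", "first", "only" and "open" are said of these compounds alone.

Measured in an ADME assay on microsomes from liver (Homo sapiens) for metabolic stability, read by LC-MS, using NADPH, with stated times of 5 min and 30 min, tested at 1 uM; on this read-out lower numbers stand for slow clearance and higher numbers for fast clearance:
Compound 1 `Cc1ncccc1-c1cnc(NCc2c(F)ccc3c2CCO3)c2nn(CC#N)c(=O)n12`: 151 mL.min-1.g-1
Compound 2 `Cc1nc(CO)ccc1-c1cnc(NCc2c(F)ccc3c2CCO3)c2cn[nH]c(=O)c12`: 11 mL.min-1.g-1
Compound 3 `CC1(C)CC(=O)N(c2cnc(NCc3c(F)ccc4c3CCO4)n3cnnc23)C1`: 16 mL.min-1.g-1

Compound 2 sits at the low end of these numbers, level with compound 3 within the scatter, while compound 1 reads far higher, a gap beyond the scatter. Compound 4 `Cc1ncccc1-c1cnc(NCc2c(F)ccc3c2CCO3)c2cn[nH]c(=O)c12` differs from compound 2 in one place: hydrogen in place of hydroxymethyl on an aromatic carbon. Among the compounds with values here, no measured pair shows this change alone. Compound 1 also carries the 2-methylpyridin-3-yl group, on another core, and gives 151 mL.min-1.g-1, so a rise beyond the scatter is expected, though probably not one that large. The estimated step is a 3.6-fold higher number from compound 2 to compound 4 (0.56 log units; beyond the scatter). For compound 4 the estimated value is 40 mL.min-1.g-1, with an expected range of 15 mL.min-1.g-1 to 110 mL.min-1.g-1.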

Compound 4, intrinsic clearance in microsomes: 41 mL.min-1.g-1
The estimate for compound 4 lay 1.0-fold (0.01 log units) below the measured number, and the stated range covers the measured number.
By their numbers in this assay, from the lowest: compounds 2 and 3 (each within the scatter of the next); then compound 4; then compound 1.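

Swapping 6-(hydroxymethyl)-2-methylpyridin-3-yl for 2-methylpyridin-3-yl on the shared core gives the first direct reading at this position: in this assay clearance rises (a 3.7-fold higher number from compound 2 to compound 4 (0.57 log units; beyond the scatter)). On this core, then, hydroxymethyl on this aromatic carbon, next to the ring nitrogen, goes with slower clearance than hydrogen does. Nothing measured here gives a cause for the step.

On these data alone, whether an amine, a methoxy group or a carboxylic acid at this carbon would read like hydroxymethyl remains open. So does whether the same change would give a similar step on the core of compound 1.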